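A few compounds are considered here, and "the series" means these few. Any claim that something is new, unique, unknown or untested is made for them only; others in the source may bear on it.

Notes on the series. The a functional assay on HepG2 cells (Homo sapiens) for inhibition, read by MTT assay (a lower number here means a stronger inhibitor, a higher number a weaker inhibitor), covers three measured amides on a shared core. Compound 1 `COc1cc2ncnc(Nc3ccc(NC(=O)c4ccccc4OC)cc3)c2cc1OC` gives only a limit of the assay, > 100000 nM. Compound 2 `COc1cc2ncnc(Nc3ccc(NC(=O)c4ccc(C(C)(C)C)cc4)cc3)c2cc1OC` likewise gives only a limit, > 100000 nM. Compound 3 `COc1cc2ncnc(Nc3ccc(NC(=O)c4cccc(Cl)c4)cc3)c2cc1OC` gives 12000 nM. The step that the two limits leave unreadable from compound 1 to compound 2 is unreadable because both values sit at the limit of > 100000 nM in this assay, at which 2 of the 3 values shown sit. The step of an at least 8.3-fold lower number from compound 2 to compound 3 (0.92 log units; beyond the scatter) shows that 3-chlorophenyl on the carbonyl carbon brings the number below that limit. Compound 4 `COc1cc2ncnc(Nc3ccc(NC(=O)c4cc(F)ccc4Br)cc3)c2cc1OC` is not yet measured; it differs from compound 2 by 2-bromo-5-fluorophenyl in place of 4-(tert-butyl)phenyl on a carbonyl carbon. The step of an at least 8.3-fold lower number from compound 2 to compound 3 (0.92 log units; beyond the scatter) bears most directly on this change, and a drop of similar size is expected, an at least 5.0-fold lower number from compound 2 to compound 4 (0.69 log units; beyond the scatter). Compound 4 is therefore estimated at 20000 nM, between 5000 nM and 100000 nM.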

Compound 4, half-maximal inhibitory concentration: 22000 nM
Beside the measured number, compound 4's estimate is 1.1-fold (0.04 log units) below it; the measured number falls inside the stated range.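

In this assay, 2-bromo-5-fluorophenyl on the carbonyl carbon also gives a measurable number, with an at least 4.5-fold lower number from compound 2 to compound 4 (0.65 log units; beyond the scatter) and an at least 4.5-fold lower number from compound 1 to compound 4 (0.65 log units; beyond the scatter), so 3-chlorophenyl is not alone in doing so. Both steps are bounds only, since compound 1 and compound 2 each give a limit: the limit of > 100000 nM in this assay, at which 2 of the 4 values shown sit. The two halogen-bearing groups are not separated, with a 1.8-fold higher number from compound 3 to compound 4 (0.26 log units; within the scatter).

Open, as far as these compounds go, is how an unsubstituted phenyl, or a phenyl carrying an amine or a carboxylic acid, would read in this assay. From the compounds shown here alone, whether either halogen is needed also stays open.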